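The source may report more compounds than this note shows. Statements on the series, on what has been measured and on what is new or still open speak of the compounds shown alone.

Working notes on the series. Compound 1 `COc1cc(C2=NN(C(C)=O)C(c3cccc(F)c3)O2)cc(OC)c1OC` was tested in a functional assay on PC-3 cells (Homo sapiens) for antiproliferative activity, read by MTT assay, tested at 1 uM (a lower number here means a weaker effect, a higher number a stronger effect of the compound at the concentration tested), where compound 1 gives 16.5%. Two further compounds share its core but carry an open-chain linker in place of the ring. Compound 2 `COc1cc(C(=O)N/N=C/c2cccc(C(F)(F)F)c2)cc(OC)c1OC` gives 51% in this assay. Compound 3 `COc1cc(C(=O)N/N=C/c2ccc(Cl)c(Cl)c2)cc(OC)c1OC` gives 13.5% in this assay. On these three numbers compound 1 stands second highest; its nearest neighbour is compound 3, whose value lies within the scatter of that of compound 1, so no order between the two can be read. Among the compounds with values here, compound 2 stands furthest away, beyond the scatter on the high side, and it is the only compound here that carries a trifluoromethyl group. Compound 2 and compound 3 differ in more than one place, so their values show only that the trifluoromethyl-bearing one is higher.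

Compound 4 `COc1cc(C2=NN(C(C)=O)C(c3cccc(C(F)(F)F)c3)O2)cc(OC)c1OC` has not yet been measured in this assay. It differs from compound 1 in one place: trifluoromethyl in place of fluoro on an aromatic carbon. Within the data shown here, no measured pair isolates this change, so its size is not known from a direct comparison; the high value of compound 2 is the only hint, and it sits on a different linker. A modest upward step is expected, a number 9.5 percentage points higher from compound 1 to compound 4 (within the scatter), which may or may not pass beyond the scatter. For compound 4 the value in this assay is estimated at 26%, within a range from 9% to 45%.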

Compound 4, a percentage reported as inhibition, at one concentration (the size of the read-out at that concentration, not a potency): 30.1%
For compound 4 the middle estimate is 4.1 percentage points below the measured one, within the range that was stated.
By their numbers in this assay, from the lowest: compounds 3 and 1 (each within the scatter of the next); then compound 4; then compound 2.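

In this assay, within the data shown here, the change from 3-fluorophenyl to 3-(trifluoromethyl)phenyl on the shared core gives a number 13.6 percentage points higher from compound 1 to compound 4 (beyond the scatter), the first pair that isolates this change at this position. The larger group, with its four heavy atoms in place of one, is therefore accepted on this aromatic carbon with a rise in the read-out rather than a loss, and the link between trifluoromethyl and a higher number no longer rests only on compound 2, which sits on the open-chain linker. The data shown offer no measured basis for explaining the step, which stands as an observation on a single pair of compounds.

Among these compounds, whether the same exchange of fluoro for trifluoromethyl would also raise the number on the open-chain linker of compound 2 and compound 3 stays open, since no single-change pair on that linker is available here. Equally open, from the compounds shown here alone, is how a different group on the same aromatic carbon, such as a methoxy, a nitrile, an amine or a carboxylic acid, would compare with compound 4 on the shared core.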